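The source may report more compounds than this note shows. Statements on the series, on what has been measured and on what is new or still open speak of the compounds shown alone.

Compound 1 `CC(=NNC(=S)Nc1ccccc1F)c1ccccn1`, compound 2 `CC(=NNC(=S)Nc1cccc(I)c1)c1ccccn1` and compound 3 `C/C(=N/NC(=S)Nc1cccc(I)c1)c1ccccn1` share one core and were all tested in a functional assay on MCF7 cells (Homo sapiens) for cytotoxicity, read by MTT assay, with a stated time of 48 h; on this read-out higher numbers stand for weaker inhibition and lower numbers for stronger inhibition. Compound 1 gives 0.39 nM, whereas compound 2 gives 45 nM and compound 3 gives 45 nM. Compound 2 thus stands level with compound 3, and these two sit at the highest numbers of the three, with compound 1 far lower. Going by the values given here, the only single-point step among the measured compounds is no change at the digits printed from compound 2 to compound 3 (within the scatter), the pair being identical in atoms and bonds and differing only in that (the fact that one of compounds 2 and 3 is drawn with a defined configuration and the other without, at the place where they differ).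

Compound 4 `CC(=NNC(=S)Nc1cccc([N+](=O)[O-])c1)c1ccccn1` is not yet measured. It differs from compound 2 by nitro in place of iodo on an aromatic carbon. Among the compounds with values here, no measured step touches a change of substituent on that ring, so the one known step offers no guidance on direction, and the expectation rests on compound 2 alone, with a wide range to cover the uncertainty. Compound 4 is therefore expected to give roughly 40 nM, somewhere between 4 nM and 400 nM. That estimate amounts to an expected step of a 1.1-fold lower number from compound 2 to compound 4 (0.05 log units; within the scatter).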

Compound 4, half-maximal inhibitory concentration: 38 nM
For compound 4 the middle estimate is 1.1-fold (0.02 log units) above the measured one; measured number inside the range.
By their numbers in this assay, from the lowest: compound 1; then compounds 4, 2 and 3 (each within the scatter of the next).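

Going by these compounds alone, this is the first measured change of substituent on this ring: on an aromatic carbon meta to a large group, nitro in place of iodo gives a 1.2-fold lower number from compound 2 to compound 4 (0.07 log units; within the scatter) in this assay. At this place, then, a single iodine atom can give way to a group of more heavy atoms that brings hydrogen-bond acceptors, and the number stays within the scatter. Nothing available bears on why these two groups read alike.

The compounds shown leave open whether an amine or a carboxylic acid at this same place would also read like iodo and nitro. Compound 1 differs from compound 2 in more than one place, so its far lower number cannot be tied to any single change.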